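A few compounds are considered here, and "the series" means these few. Any claim that something is new, unique, unknown or untested is made for them only; others in the source may bear on it.

Compound 1 `COc1ccc(C2=C(c3cc(OC)c(OC)c(OC)c3)C(=O)C(OC(C)=O)C2)cc1O`: in an ADME assay on KB cells (Homo sapiens) for cytotoxicity, read by MTT assay, with a stated time of 72 h (on this read-out higher numbers stand for weaker inhibition and lower numbers for stronger inhibition), compound 1 gives 35 ug/mL.
Compound 2 `COc1ccc(C2=C(c3cc(OC)c(OC)c(OC)c3)CC(O)C2=O)cc1N`: for compound 2 the result in this assay is a limit of the assay, not a number, namely < 1 ug/mL.
Compound 3 `COc1ccc(C2=C(c3cc(OC)c(OC)c(OC)c3)C(=O)CC2O)cc1`: for compound 3 the entry in this assay reads "not determined" (no result reported), so no result is reported.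

Compound 3 therefore has no number of its own to stand on; of the three values shown, one is a plain number and one is the limit of < 1 ug/mL in this assay, at which 1 of the 3 values shown sits, so the series is spanned by one measured value and one limit. Compound 4 `COc1cc(C2=C(c3ccc(OCC(=O)O)cc3)C(O)CC2=O)cc(OC)c1OC` differs from compound 3 by carboxy in place of hydrogen on a saturated chain carbon bound to an oxygen on an aromatic ring. Among the compounds with values here, with no measured pair sharing this change, no step size can be taken from the data, and compound 3 itself gives no anchor. Within the data shown here, the only numbers in this assay come from compound 1 and from compound 2, both built on the shared core but carrying other substituents. The expectation for compound 4 is a weak value in this assay, comparable to the number for compound 1, with wide uncertainty in both directions. Compound 4 is estimated at 30 ug/mL, in the range 5 ug/mL to 100 ug/mL.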

Compound 4, half-maximal inhibitory concentration: > 100 ug/mL
Compound 4: no number, only a limit; the forecaster's own chance of this, stated with the estimate: 20%; at least 3.3-fold (0.52 log units) between middle value and limit.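

No new step can be read between compound 3 and compound 4: the entry for compound 3 holds no number, and in this assay compound 4 gives only a limit, > 100 ug/mL. The compounds shown leave open how far methoxy to carboxymethoxy alone shifts the value on the shared core.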